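This account rests on a few compounds, and the source may have more. Where it says the series, first, only, none or still open, it means among the compounds named here.

Compound 3 `C#CCCCCOc1cc(O)c(C(C)=O)cc1CC=C` gives 74% in an assay on isolated protein for inhibition of leukotriene B4 receptor 1 (Homo sapiens), tested at 10 uM (on this read-out lower numbers stand for less inhibition and higher numbers for more inhibition at the one concentration tested (going by the name of the read-out)), the lowest of the three numbers shown. Its nearest neighbour is compound 1 `C=CCc1cc(C(C)=O)c(O)cc1OCCCCCC#N`, which gives 81%; compound 2 `C=CCc1cc(C(C)=O)c(O)cc1OCCCCCCCC#N` gives 88%. The steps are a number 7 percentage points lower from compound 1 to compound 3 (within the scatter) and a number 14 percentage points lower from compound 2 to compound 3 (beyond the scatter), while a number 7 percentage points higher from compound 1 to compound 2 (within the scatter). Compound 4 `C=CCc1cc(C(C)=O)c(O)cc1OCCCCCC(=O)NO` differs from compound 3 in one place: (hydroxycarbamoyl)methyl in place of ethynyl on a saturated chain carbon, four bonds along the chain from an oxygen on an aromatic ring. Going by the values given here, no measured step carries a hydroxycarbamoyl group, so the steps to compounds 1 and 2, both replacing ethynyl with a longer nitrile-bearing chain, are the only guide, and they were modest. Compound 4 is therefore expected to remain close to compound 3, with a number 2 percentage points lower from compound 3 to compound 4 (within the scatter) expected to lie within the scatter. The estimate for compound 4 is 72%, between 50% and 90%.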

Compound 4, a percentage reported as inhibition, at one concentration (the size of the read-out at that concentration, not a potency): 85%
Compound 4: middle estimate off by 13 percentage points, on the low side; the range from low to high includes it.
By their numbers in this assay, from the lowest: compounds 3, 1, 4 and 2 (each within the scatter of the next, the first and the last beyond it).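

In this assay (hydroxycarbamoyl)methyl in place of ethynyl gives a number 11 percentage points higher from compound 3 to compound 4 (beyond the scatter) at this place on the chain. Against the nitrile-ended chains, the hydroxycarbamoyl end gives a number 4 percentage points higher from compound 1 to compound 4 (within the scatter) and a number 3 percentage points lower from compound 2 to compound 4 (within the scatter) and so cannot be told apart from a nitrile here, even though it brings hydrogen-bond donors. Nothing measured here explains these numbers. From the compounds shown here alone, whether a carboxylic acid or an amine at the chain end would read like compound 4 stays open, as does the effect of a longer chain carrying the hydroxycarbamoyl group.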